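Adding propargyloxy to a fluoro-chloro aryl compound

This account rests on a few compounds, and the source may have more. Where it says the series, first, only, none or still open, it means among the compounds named here.

Measured so far in a functional assay on the whole organism with Scenedesmus acutus as the target, with a stated time of 20 h; on this read-out lower numbers stand for stronger inhibition and higher numbers for weaker inhibition:
compound 1 `Cc1cc(Cl)ccc1/N=c1\sc(=S)n2n1CCCC2`: 513 nM
compound 2 `Fc1cc(Cl)ccc1/N=c1\sc(=S)n2n1CCCC2`: 91.2 nM

Compound 2 holds the lower of the two numbers, and the gap between the two compounds lies beyond the scatter. Within the data shown here, that gap is the only measured step: a 5.6-fold lower number from compound 1 to compound 2 (0.75 log units; beyond the scatter), which is modest and comes from fluoro in place of methyl on an aromatic carbon.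

Compound 3 `C#CCOc1cc(/N=c2\sc(=S)n3n2CCCC3)c(F)cc1Cl` keeps the fluoro and chloro groups of compound 2 and changes the ring elsewhere: propargyloxy in place of hydrogen on an aromatic carbon. Among the measured compounds shown here, no measured step covers propargyloxy in place of hydrogen, so the direction is a tentative expectation. The only gauge of size is a 5.6-fold lower number from compound 1 to compound 2 (0.75 log units; beyond the scatter), and a step of similar modest size toward a lower number is expected in this assay. The estimate amounts to an expected step of a 3.0-fold lower number from compound 2 to compound 3 (0.48 log units; beyond the scatter). For compound 3 the estimated value is 30 nM, within an expected range of 6 nM to 150 nM.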

Compound 3, half-maximal inhibitory concentration: 79.4 nM
Beside the measured number, compound 3's estimate is 2.6-fold (0.42 log units) below it; low and high end bracket the measured number.
By their numbers in this assay, from the lowest: compounds 3 and 2 (each within the scatter of the next); then compound 1.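

In this assay the aromatic position ortho to the chloro group and para to the fluoro group takes propargyloxy in place of hydrogen without a change in the number beyond the scatter (a 1.1-fold lower number from compound 2 to compound 3 (0.06 log units; within the scatter)). The fluoro and chloro pattern of compound 2 therefore keeps its standing with this extra chain on the ring, so this position accepts a group of this size in this assay. The earlier fluoro in place of methyl step (a 5.6-fold lower number from compound 1 to compound 2 (0.75 log units; beyond the scatter)) lay beyond the scatter, whereas this change does not, and nothing measured here bears on why the number holds.

As far as these compounds go, whether a methoxy group, an amine or a longer chain at this position would also leave the number level remains open. So does whether propargyloxy would behave the same on compound 1, with its methyl group in place of fluoro.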